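The compounds below may be only part of what the source reports. "The series", "measured", "known", "first", "only" and "open" are said of these compounds alone.

Working notes on the series. Compound 1 `C=C1c2c(C)nc(OC)c(C#N)c2N=CN1CCCCCC`, compound 2 `C=C1c2c(C)nc(OC)c(C#N)c2N=CN1Cc1ccco1` and compound 3 `C=C1c2c(C)nc(OC)c(C#N)c2N=CN1Cc1ccccc1` share one core and differ only in the group on the saturated chain carbon bound to the ring nitrogen. In a functional assay on KB cells (Homo sapiens) for cytotoxicity, read by MTT assay, with a stated time of 3 days (on this read-out higher numbers stand for weaker inhibition and lower numbers for stronger inhibition), compound 1 gives > 50000 nM, which is a limit of the assay and not a number. In this assay compound 2 gives > 50000 nM, again a limit. In this assay compound 3 gives > 50000 nM, also a limit. Compound 3 therefore stands where the other two stand, at the limit of > 50000 nM in this assay, at which 3 of the 3 values shown sit, and the steps a step that the two limits leave unreadable from compound 1 to compound 2, a step that the two limits leave unreadable from compound 1 to compound 3 and a step that the two limits leave unreadable from compound 2 to compound 3 cannot be read in size or direction because the limit of > 50000 nM in this assay, at which 3 of the 3 values shown sit, hides them.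

Compound 4 `C=C1c2c(C)nc(OC)c(C#N)c2N=CN1Cc1ccc(Cl)cc1` is not yet measured. It differs from compound 3 by chloro in place of hydrogen on an aromatic carbon. Among the measured compounds shown here, no measured step bears on this change, as every step among compounds 1, 2 and 3 is unreadable, and the three values give no sign that any group at this position brings the series below the limit. The expectation for compound 4 in this assay is therefore a step that the limit leaves unreadable from compound 3 to compound 4 of no readable size. Compound 4 is estimated at 100000 nM in this assay, with a range from 30000 nM to 400000 nM, and most likely reported only as a limit.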

Compound 4, half-maximal inhibitory concentration: 20000 nM
Compound 4: middle estimate off by 5.0-fold (0.70 log units), on the high side, outside the stated range (below it).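

In this assay, among the compounds shown here, chloro in place of hydrogen on an aromatic carbon, para to a large group, gives the first readable step, an at least 2.5-fold lower number from compound 3 to compound 4 (0.39 log units; beyond the scatter), showing that the group on the saturated chain carbon can respond to a single added atom, which compounds 1, 2 and 3 could not show. The 4-chlorophenyl group reads the same way against furan-2-yl, an at least 2.5-fold lower number from compound 2 to compound 4 (0.39 log units; beyond the scatter), and against pentyl, an at least 2.5-fold lower number from compound 1 to compound 4 (0.39 log units; beyond the scatter), while the steps among the three earlier compounds remain unreadable. All three new steps give only a least size, and the full size of each stays hidden because the earlier compounds sit at a limit: the limit of > 50000 nM in this assay, at which 3 of the 4 values shown sit.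

On these data alone, whether this step belongs to chloro itself or would also appear with another group at the same place, such as fluoro, methoxy or an amine, remains open. Also open, as far as these compounds go, is whether a second chloro on the same ring, or a chloro on the furan-2-yl ring of compound 2, would bring the number lower than in compound 4.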